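Swapping the amide aryl for a difluorocyclohexyl ring

A few compounds are considered here, and "the series" means these few. Any claim that something is new, unique, unknown or untested is made for them only; others in the source may bear on it.

The three measured compounds share a core seen in compound 1 `O=C(c1cccc(F)c1)N1CC(c2nc(-c3cccc(Cl)c3)no2)C1`, compound 2 `Cc1cccc(-c2noc(C3CN(C(=O)c4cccc(F)c4)C3)n2)c1` and compound 3 `O=C(c1ccc(Cl)cc1)N1CC(c2nc(-c3cccc(F)c3)no2)C1`. In an assay on HEK293 cells for positive allosteric modulation of metabotropic glutamate receptor 5 (Homo sapiens), read by FLIPR (a higher number here means that more compound is needed for the effect, a lower number that less compound is needed), compound 1 reaches only the limit of the assay, > 10000 nM. In this assay compound 2 likewise reaches only the limit, > 10000 nM. Compound 3 gives 2500 nM in this assay. Among the compounds with values here, the one single-point step, a step that the two limits leave unreadable from compound 1 to compound 2, cannot be read because the limit of > 10000 nM in this assay, at which 2 of the 3 values shown sit, holds both of its ends.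

Compound 4 `Cc1cccc(-c2noc(C3CN(C(=O)C4CCC(F)(F)CC4)C3)n2)c1` is not yet measured. It differs from compound 2 as follows (4,4-difluorocyclohexyl in place of 3-fluorophenyl on a carbonyl carbon). Within the data shown here, no measured step touches the group on the carbonyl carbon: compound 3 carries a different aryl there, but it also differs from compound 2 elsewhere, so its value stands alone. With compound 2 at the limit, nothing shows which way the change will carry.

The author therefore expects compound 4 to give about 6000 nM in this assay, between 1500 nM and 25000 nM, with a fair chance that only a limit is reported again. That estimate means a step of an at least 1.6-fold lower number from compound 2 to compound 4 (0.22 log units; that floor lies within the scatter), expected only loosely.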

Compound 4, half-maximal effective concentration: 590 nM
For compound 4 the middle estimate is 10-fold (1.01 log units) above the measured one; the whole stated range lies above it.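

In this assay, the group on the carbonyl carbon turns out to be a place where a change can bring this series clear of the assay limit: 4,4-difluorocyclohexyl in place of 3-fluorophenyl gives an at least 16-fold lower number from compound 2 to compound 4 (1.22 log units; beyond the scatter). Within the data shown here, the earlier compounds carried only substituted phenyl groups on this carbonyl carbon, and none of them formed a readable step there, so this is the first sign that the position does not need an aromatic ring and that a non-aromatic ring of carbon only can serve better than the 3-fluorophenyl group of compound 2. The true size of the step remains unknown, and the printed figure is only a floor, because compound 2 has no numerical value of its own: the limit of > 10000 nM in this assay, at which 2 of the 4 values shown sit.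

The compounds shown leave open whether the fluorines or the non-aromatic ring itself carries the step, a question that a plain cyclohexyl or a tetrahydropyranyl ring on the carbonyl carbon would address. Going by these compounds, it also remains open whether the same swap would hold with the chloro group of compound 1 in place of the methyl group of compound 4.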